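Three Measured Compounds and a Fourth Awaiting Its Number

The source may hold more compounds than are shown below. What is called first, only, known or untested is meant among the compounds shown, and "the series" means these compounds.

In an ADME assay on the whole organism with Oryza sativa as the target, tested at 10 uM (on this read-out lower numbers stand for a stronger effect and higher numbers for a weaker effect at the one concentration tested), the three measured compounds gave these readings:

Compound 1 `CCCCCc1ccc(NC(=O)N[C@@H](C)c2ccccc2)cc1`: 93%
Compound 2 `CCCCCCCc1ccc(NC(=O)N[C@@H](C)c2ccccc2)cc1`: 99%
Compound 3 `C[C@H](NC(=O)Nc1ccc(C(F)(F)F)cc1)c1ccccc1`: 94%

Compound 3 holds the second highest of the three numbers, and both of its neighbours sit within the scatter: a number 1 percentage points higher from compound 1 to compound 3 (within the scatter) and a number 5 percentage points lower from compound 2 to compound 3 (within the scatter). Compound 4 `C[C@H](NC(=O)Nc1ccc(F)cc1)c1ccccc1` differs from compound 3 at that same aromatic carbon: fluoro in place of trifluoromethyl on an aromatic carbon. Going by the values given here, the steps that bear on this change are the two earlier swaps of the group on that aromatic carbon, a number 1 percentage points higher from compound 1 to compound 3 (within the scatter) and a number 5 percentage points lower from compound 2 to compound 3 (within the scatter), and the chain lengthening a number 6 percentage points higher from compound 1 to compound 2 (within the scatter); all three stayed within the scatter. No step beyond the scatter is therefore expected for compound 4: a number 1 percentage points higher from compound 3 to compound 4 (within the scatter). The estimate for compound 4 is 95%, expected to fall between 84% and 100%.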

Compound 4, a percentage reported as activity, at one concentration (the size of the read-out at that concentration, not a potency): 85%
Compound 4: the middle estimate sits 10 percentage points above what was measured; the measured number falls inside the stated range.
By their numbers in this assay, from the lowest: compounds 4, 1, 3 and 2 (each within the scatter of the next, the first and the last beyond it).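

Going by these compounds alone, at this aromatic carbon, fluoro gives the first step beyond the scatter in this assay, with heptyl leaving: [ a number 14 percentage points lower from compound 2 to compound 4 (beyond the scatter) ]. Against the other two groups the change stays within the scatter, both for trifluoromethyl, [ a number 9 percentage points lower from compound 3 to compound 4 (within the scatter) ], and for pentyl, [ a number 8 percentage points lower from compound 1 to compound 4 (within the scatter) ]. No measurement at hand accounts for this step.

Still open, going by these compounds, is how chloro, an amine or a carboxylic acid on this same carbon would read. Also open, on these data alone, is whether any of them would separate from compound 4 beyond the scatter.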